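Cytotoxicity of three acyclic nucleoside analogues on fibroblasts

This account rests on a few compounds, and the source may have more. Where it says the series, first, only, none or still open, it means among the compounds named here.

This account follows two measured compounds and one unmeasured analogue in an ADME assay on HFF cells (Homo sapiens) for cytotoxicity, with a stated time of 8 days; a higher number here means that more compound is tolerated, a lower number that less compound is tolerated. Compound 1 `CNc1nc(N)nc2c1ncn2/C=C1/CC1(CO)CO` gives 265000 nM in this assay. Compound 2 `COCCOc1nc(N)nc2c1ncn2/C=C1/CC1(CO)CO` reaches only the limit of this assay, > 300000 nM, so no number is known for it. The step of an at least 1.1-fold higher number from compound 1 to compound 2 (0.05 log units; that floor lies within the scatter) therefore rests on the limit of > 300000 nM in this assay, at which 1 of the 2 values shown sits, and shows no difference beyond the scatter. Compound 3 `Nc1nc(N2CCCC2)c2ncn(/C=C3/CC3(CO)CO)c2n1` differs from compound 2 by pyrrolidin-1-yl in place of 2-methoxyethoxy on an aromatic carbon. Among the measured compounds shown here, no measured step concerns the same position with this group, and the only measured step, from compound 1 to compound 2, lies within the scatter. For compound 3 the step of an at least 1.0-fold lower number from compound 2 to compound 3 (0.02 log units; that floor lies within the scatter) is therefore expected to be small in this assay. Compound 3 is estimated to give 280000 nM in this assay, with a range from 130000 nM to 600000 nM.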

Compound 3, half-maximal cytotoxic concentration: > 300000 nM
Compound 3: a limit, no number; the forecaster's own chance of this, stated with the estimate: 55%; middle value at least 1.0-fold (0.02 log units) from the limit.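

In this assay compound 3 gives > 300000 nM and this is a limit of the assay, not a number. Among the compounds shown here, the only new step that can be read is an at least 1.1-fold higher number from compound 1 to compound 3 (0.05 log units; that floor lies within the scatter) with pyrrolidin-1-yl in place of methylamino, so a ring on this aromatic carbon brings no change beyond the scatter; the steps that rest on two limits cannot be read. Pyrrolidin-1-yl thus ends at the same limit as 2-methoxyethoxy, and the top of the range now holds most of the series: the limit of > 300000 nM in this assay, at which 2 of the 3 values shown sit.

Going by these compounds, how far compound 2 and compound 3 lie from each other stays open, as does whether any group at this position lowers the number beyond the scatter. A piperazine, a carboxylic acid or a longer chain on this aromatic carbon remains untested in the compounds shown here.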